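This account rests on a few compounds, and the source may have more. Where it says the series, first, only, none or still open, it means among the compounds named here.

So far two compounds have numbers. In a functional assay on NCI-H460 cells (Homo sapiens) for antiproliferative activity, read by sulforhodamine B assay, with a stated time of 48 h (on this read-out lower numbers stand for stronger inhibition and higher numbers for weaker inhibition), compound 1 (`O=C(CCCCCCN1C(=O)/C(=N\O)c2cc(Cl)ccc21)NO`) gives 850 nM and compound 2 (`CO/N=C1/C(=O)N(CCCCCCC(=O)NO)c2ccccc21`) gives 750 nM on the same read-out. These two values lie within the usual scatter of repeated measurements, so compound 2 stands level with compound 1, and neither can be ranked above the other.

The next compound is compound 3 (`CO/N=C1/C(=O)N(CCCCCCC(=O)NO)c2ccc(Cl)cc21`), which differs from compound 2 in one place, and chloro in place of hydrogen on an aromatic carbon sums up that difference: chloro in place of hydrogen on an aromatic carbon.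

For the measured compounds named here, no two measured compounds differ by this change alone, so the data give no direct size for it. Going by the values given here, the only hint is that compound 1, which also carries a chloro, gives 850 nM in this assay and so sits within the scatter of compound 2. No step beyond the scatter is therefore expected in either direction. The estimated step of a 1.3-fold lower number from compound 2 to compound 3 (0.10 log units; within the scatter) reflects that expectation. For compound 3 the expected value is 600 nM with a likely range from 250 nM to 1400 nM on this read-out.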

Compound 3, half-maximal inhibitory concentration: 760 nM
For compound 3 the middle estimate is 1.3-fold (0.10 log units) below the measured one; low and high end bracket the measured number.
By their numbers in this assay, from the lowest: compounds 2, 3 and 1 (each within the scatter of the next).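

In this assay, for the compounds shown here, the change can now be read directly for the first time, as a 1.0-fold higher number from compound 2 to compound 3 (0.01 log units; within the scatter), so compound 2 and compound 3 stand level. This shows that this aromatic carbon of the shared core can carry a chloro in place of hydrogen with the number staying within the scatter, although this rests on a single pair of compounds and sets no general rule. Nothing measured here offers an explanation for this result.

Still open, as far as these compounds go, is whether a fluoro, a methoxy or a trifluoromethyl on this same aromatic carbon would also stand level with compound 2, or whether an amine or a carboxylic acid there would give a clearly different number. Going by these compounds alone, also open is whether a chloro would give the same outcome on the other aromatic carbons of this six-membered ring, and whether a longer chain in place of the one in compound 3 would keep its number within the scatter.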